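This account rests on a few compounds, and the source may have more. Where it says the series, first, only, none or still open, it means among the compounds named here.

Of the compounds shown here, two have numbers so far in an ADME assay on microsomes from liver (Mus musculus) for metabolic stability, read by LC-MS, with a stated time of 30 min, tested at 1 uM; on this read-out lower numbers stand for a less stable compound and higher numbers for a more stable compound. Compound 1 (`CC(C)(C)NCc1cc(Cl)cc(Nc2nc3cc(F)c(F)cc3n2Cc2ccc(C(F)(F)F)cc2)c1O`) gives 94%. Going by the values given here, compound 2 (`CCNCc1cc(Cl)cc(Nc2nc3cc(F)c(F)cc3[nH]2)c1O`) gives 98%, and the two values lie within the scatter of each other, so compound 2 stands level with the only other measured compound. Among the compounds with values here, compound 3 (`CCNCc1cc(Cl)cc(Nc2nc3cc(F)c(F)cc3n2Cc2ccc(C(F)(F)F)cc2)c1O`) has no measurement yet and follows from compound 2 by one change, 4-(trifluoromethyl)benzyl in place of hydrogen on an aromatic nitrogen. Within the data shown here, no measured pair isolates this change, so the expectation rests on thin ground. Compound 1 also bears 4-(trifluoromethyl)benzyl and gives 94%, so no step beyond the scatter is expected in this assay. The expected change is a number 7 percentage points lower from compound 2 to compound 3 (within the scatter), a slight fall in the number. The estimated value for compound 3 is 91%, with an expected range of 78% to 99%.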

Compound 3, percent of the compound remaining: 86%
Compound 3: the middle estimate sits 5 percentage points above what was measured; measured number inside the range.
By their numbers in this assay, from the lowest: compounds 3, 1 and 2 (each within the scatter of the next, the first and the last beyond it).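

In this assay the 4-(trifluoromethyl)benzyl group on the aromatic nitrogen now has its first direct read, with ethyl held on the amine nitrogen: the step is a number 12 percentage points lower from compound 2 to compound 3 (beyond the scatter) and counts as modest. With that group in place, the amine nitrogen also has its first read, and the change gives a number 8 percentage points lower from compound 1 to compound 3 (within the scatter) and so does not separate ethyl from tert-butyl in this series. Nothing on hand gives a reason for either step.

From the compounds shown here alone, whether the step belongs to the benzyl group as a whole or to its trifluoromethyl stays open, and a plain benzyl or a methyl on the same nitrogen would help to separate the two. Also open, going by these compounds, is whether the step recurs with tert-butyl on the amine nitrogen, or with a longer chain there.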